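This account rests on a few compounds, and the source may have more. Where it says the series, first, only, none or still open, it means among the compounds named here.

Measured compounds:
compound 1, `COc1ccc(Cl)cc1C(=O)NCCC1CCN(S(=O)(=O)NC(=O)NC[C@@H]2C[C@@H]3C=C[C@@H]2C3)CC1`, gives 37% in a functional assay on the whole organism (blood) with Rattus norvegicus as the target, with stated times of 24 h and 1 h, at a dose of 5 mg/kg by the intraperitoneal route; a lower number here means a weaker effect, a higher number a stronger effect of the compound at the dose given.
compound 2, `COc1ccc(Cl)cc1C(=O)NCCC1CCN(S(=O)(=O)NC(=O)NC[C@@H]2C[C@@H]3CC[C@@H]2O3)CC1`, gives 30% in this assay.

Only these two numbers exist, and they lie close together: the step of a number 7 percentage points lower from compound 1 to compound 2 (within the scatter) is the whole record so far. Compound 2 therefore cannot be placed above or below compound 1 on these data; the two are, for practical purposes, level.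

Compound 3, `COc1ccc(Cl)cc1C(=O)NCCC1CCN(S(=O)(=O)NC(=O)NC[C@H]2C[C@@H]3CC[C@@H]2O3)CC1`, has not yet been measured in this assay. It differs from compound 2 as follows: the two compounds have the same atoms and bonds and differ only in configuration as drawn: 1 of 3 stereo elements differ; a stereocentre at a saturated ring carbon is drawn S in compound 2 and R in compound 3.

For the measured compounds named here, no measured step speaks to a change of configuration alone. Going by the values given here, the single step available, from compound 1 to compound 2, exchanged one ring pair for another and stayed inside the scatter, so it offers no hint of a direction for a change that moves no atom at all. With nothing pointing either way, compound 3 is expected to land near compound 2, and the step of no change at the digits printed from compound 2 to compound 3 (within the scatter) is expected to stay within the scatter.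

The estimate for compound 3 in this assay is therefore 30%, with a range from 15% to 45%.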

Compound 3, a percentage reported as activity, at one dose (the size of the read-out at that dose, not a potency): 27%
For compound 3 the middle estimate is 3 percentage points above the measured one; low and high end bracket the measured number.
By their numbers in this assay, from the lowest: compounds 3, 2 and 1 (each within the scatter of the next).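

For the compounds shown here, this is the first comparison that tests spatial arrangement alone, and it is a clean one for a single reason: the fact that compounds 2 and 3 differ only in the configuration as drawn. Redrawing the saturated ring carbon from S to R, which keeps every atom and bond but changes their arrangement in space at that centre, gives a number 3 percentage points lower from compound 2 to compound 3 (within the scatter) in this assay, so at this one dose the read-out does not distinguish the two forms at this stereocentre. The comparison with the all-carbon group gives a number 10 percentage points lower from compound 1 to compound 3 (within the scatter), which means that this exchange of a group of 7 heavy atoms also stays inside the scatter when the oxygen-containing group carries the R centre.

Going by these compounds, the other two stereo elements keep the same configuration in compound 2 and compound 3, so what happens when they are inverted remains open, as does whether the same indifference would hold at another dose. Also open, on these data alone, is whether a quite different group on the saturated chain carbon, such as a phenyl ring or a ring bearing a carboxylic acid, would move the read-out beyond the scatter.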